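The compounds below may be only part of what the source reports. "The series", "measured", "known", "first", "only" and "open" are said of these compounds alone.

In a functional assay on HepG2 cells (Homo sapiens) for antiproliferative activity, read by MTT assay, with a stated time of 72 h (on this read-out higher numbers stand for weaker inhibition and lower numbers for stronger inhibition), compound 1 `COc1ccc(N2C(=O)COc3ccc(-c4ccc(O)cc4)cc32)cc1` gives 10800 nM. Compound 2 `COc1ncc(-c2ccc3c(c2)N(C2CCCCC2)C(=O)CO3)cc1NS(=O)(=O)c1ccc(F)cc1` reads > 40000 nM, which is a limit of the assay and not a number. Compound 3 `CC(C)N1C(=O)COc2ccc(-c3cccc(NS(=O)(=O)c4ccc(F)cc4)c3)cc21` reads > 40000 nM, also a limit and not a number. This places compound 3 at the limit of > 40000 nM in this assay, at which 2 of the 3 values shown sit. Compound 4 `O=C1COc2ccc(-c3cccc(NS(=O)(=O)c4ccc(F)cc4)c3)cc2N1C1CCCCC1` has cyclohexyl in place of isopropyl on an amide-type nitrogen in a ring. Among the compounds with values here, no measured pair isolates this change. Compound 2, which also carries cyclohexyl, offers one clue, since > 40000 nM is its limit in this assay. The estimated step of a number no higher from compound 3 to compound 4 (the limit leaves the size open) is expected to stay within the scatter, in neither direction. For compound 4, the expected value is 40000 nM, with an estimated range of 15000 nM to 80000 nM.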

Compound 4, half-maximal inhibitory concentration: 35900 nM
The estimate for compound 4 lay 1.1-fold (0.05 log units) above the measured number; low and high end bracket the measured number.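

In this assay, cyclohexyl in place of isopropyl on the amide-type nitrogen in a ring gives an at least 1.1-fold lower number from compound 3 to compound 4 (0.04 log units; that floor lies within the scatter). Within the data shown here, compound 4 thus provides the first real number for a compound carrying cyclohexyl at this position, but the change cannot be called a gain. Compound 3 reads only a limit, not a number, so the true size of the step remains unknown: the limit of > 40000 nM in this assay, at which 2 of the 4 values shown sit.

On these data alone, it remains open how a chain ending in an amine or a carboxylic acid at this nitrogen would read. The compounds shown also do not tell whether a smaller group, such as methyl, would move the number.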